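Replacing 3-fluorophenyl with 2,3-dimethoxyphenyl on a shared core

The source may hold more compounds than are shown below. What is called first, only, known or untested is meant among the compounds shown, and "the series" means these compounds.

Compound 1 `COc1cc(/C=C/C(=O)/C(=C/c2cc(OC)c(OC)c(OC)c2)C(C)=O)cc(OC)c1OC` gives 530 nM 
Compound 2 `COc1ccc(/C=C/C(=O)/C=C/c2cc(OC)c(OC)c(OC)c2)cc1OC` gives 1210 nM 
Compound 3 `COc1ccc(/C=C/C(=O)C(=Cc2cccc(F)c2)C(=O)/C=C/c2ccc(OC)c(OC)c2)cc1OC` gives 580 nM 

All three compounds were tested in a functional assay on A549 cells (Homo sapiens) for inhibition, read by sulforhodamine B assay, with a stated time of 48 h (a lower number here means a stronger inhibitor of growth, a higher number a weaker inhibitor of growth), and these are their values. Compound 3 stands second highest of the three numbers. It lies within the scatter of compound 1, while compound 2 gives a higher number, beyond the scatter. Compound 4 `COc1ccc(/C=C/C(=O)C(=Cc2cccc(OC)c2OC)C(=O)/C=C/c2ccc(OC)c(OC)c2)cc1OC` has 2,3-dimethoxyphenyl in place of 3-fluorophenyl on a double-bonded chain carbon bound to a double-bonded chain carbon and has not yet been measured. Among the compounds with values here, no measured pair shows a comparable single change. In this assay no step beyond the scatter is therefore expected, in either direction. Compound 4 is estimated at 650 nM with an expected range from 250 nM to 1600 nM for its measurement.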

Compound 4, concentration for 50% growth inhibition: 670 nM
Compound 4: middle estimate off by 1.0-fold (0.01 log units), on the low side; low and high end bracket the measured number.
By their numbers in this assay, from the lowest: compounds 1, 3, 4 and 2 (each within the scatter of the next, the first and the last beyond it).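

In this assay, within the data shown here, placing 2,3-dimethoxyphenyl in place of 3-fluorophenyl on a double-bonded chain carbon bound to a double-bonded chain carbon gives a 1.2-fold higher number from compound 3 to compound 4 (0.06 log units; within the scatter), the first single change that can be read at this position. The position therefore accepts a group with more heavy atoms and with hydrogen-bond acceptors that 3-fluorophenyl lacks, with no step beyond the scatter. No measurement at hand accounts for this outcome. From the compounds shown here alone, what remains open is how the number would respond to an amine or a carboxylic acid at this position. Going by these compounds, it is also open whether this change would behave alike on another core.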